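A few compounds are considered here, and "the series" means these few. Any claim that something is new, unique, unknown or untested is made for them only; others in the source may bear on it.

Measured so far:
- compound 1 `CCCCCCCCCCCCCCCCc1c(C)c(N(C)C)nc(C)c1O`: 11%
- compound 2 `CCCCCCCCCCc1c(C)c(N(C)C)nc(C)c1O`: 19%

In a functional assay on cells (Lymphocyte, Homo sapiens), read by trypan blue exclusion, with a stated time of 16 h, tested at 0.1 uM (on this read-out lower numbers stand for a weaker effect and higher numbers for a stronger effect at the one concentration tested), compound 1 gives 11%, the lowest of the two numbers, but its nearest neighbour, compound 2, sits only a number 8 percentage points higher from compound 1 to compound 2 (within the scatter), so the two read as equal within the scatter. Among the measured compounds shown here, the only step measured so far, from compound 1 to compound 2, is hydrogen in place of hexyl on a saturated chain carbon and it changed the read-out by a number 8 percentage points higher from compound 1 to compound 2 (within the scatter).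

Compound 3 `CCCCCCCCCCCCCCCCc1c(C)c(N2CCC2)nc(C)c1O` differs from compound 1 in that (azetidin-1-yl in place of dimethylamino on an aromatic carbon). For the measured compounds named here, no measured step touches the amine, so the one available step bears on it only as a hint that the series is flat at this concentration. A step of no size beyond the scatter is therefore expected, in either direction, giving a number 4 percentage points higher from compound 1 to compound 3 (within the scatter).

Compound 3 is estimated to give 15%, with a range from 4% to 32%.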

Compound 3, a percentage reported as activity, at one concentration (the size of the read-out at that concentration, not a potency): 18%
The estimate for compound 3 lay 3 percentage points below the measured number, within the range that was stated.
By their numbers in this assay, from the lowest: compounds 1, 3 and 2 (each within the scatter of the next).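

Among the compounds shown here, the only measured change at this position, on the aromatic carbon next to the ring nitrogen, puts azetidin-1-yl in place of dimethylamino, and in this assay it gives a number 7 percentage points higher from compound 1 to compound 3 (within the scatter). The four-membered non-aromatic ring therefore cannot be told apart from dimethylamino at the one concentration tested, so the amine position, like the chain, shows no step beyond the scatter among the compounds shown. Nothing available speaks to the reason for this result.

Still open, on these data alone, is whether piperidin-1-yl, morpholin-4-yl or a primary amine at this position would move the read-out beyond the scatter. Also open, as far as these compounds go, is how azetidin-1-yl reads when paired with the shorter chain of compound 2.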